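Bromobenzyl Triazole Chalcones: Growth Inhibition Notes

A few compounds are considered here, and "the series" means these few. Any claim that something is new, unique, unknown or untested is made for them only; others in the source may bear on it.

Measured in a functional assay on HepG2 cells (Homo sapiens) for inhibition, read by MTT assay, with a stated time of 48 h, tested at 10 uM; on this read-out lower numbers stand for less inhibition of growth and higher numbers for more inhibition of growth at the one concentration tested:
compound 1 `COc1ccc(C(=O)/C=C/c2ccc(OCc3cn(Cc4cccc(Br)c4)nn3)cc2)cc1`: 27%
compound 2 `COc1ccc(C(=O)/C=C/c2ccc(OCc3cn(Cc4ccc(Br)cc4)nn3)cc2)cc1`: 59%
compound 3 `O=C(/C=C/c1ccc(OCc2cn(Cc3cccc(Br)c3)nn2)cc1)c1ccc([N+](=O)[O-])cc1`: 13%

Two changes are covered. The first is 4-bromophenyl in place of 3-bromophenyl on a saturated chain carbon bound to an aromatic nitrogen, which gives a number 32 percentage points higher from compound 1 to compound 2 (beyond the scatter). The second alters the core: nitro in place of methoxy on an aromatic carbon, which gives a number 14 percentage points lower from compound 1 to compound 3 (beyond the scatter). Compound 3 stands lowest of the three measured numbers in this assay.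

Compound 4 `O=C(/C=C/c1ccc(OCc2cn(Cc3ccc(Br)cc3)nn2)cc1)c1ccc([N+](=O)[O-])cc1` is not yet measured. It differs from compound 3 by 4-bromophenyl in place of 3-bromophenyl on a saturated chain carbon bound to an aromatic nitrogen, the same change that separates compound 1 from compound 2, at the same place in the same words. Going by the values given here, only that single earlier instance is available, so the expectation for compound 4 in this assay rests on it alone: a step of a number 25 percentage points higher from compound 3 to compound 4 (beyond the scatter) is expected from compound 3 to compound 4, comparable in direction to the earlier step and tempered somewhat because a number 14 percentage points lower from compound 1 to compound 3 (beyond the scatter) shows the nitro-bearing core starting from a lower number. Compound 4 is estimated at 38% in this assay, within a range from 18% to 58%.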

Compound 4, percent growth inhibition at one concentration: 21%
Beside the measured number, compound 4's estimate is 17 percentage points above it; the measured number falls inside the stated range.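

On the nitro-bearing core, the change from 3-bromobenzyl to 4-bromobenzyl gives a number 8 percentage points higher from compound 3 to compound 4 (within the scatter) in this assay, so the clear rise seen on the methoxy-bearing core does not carry over: the same change on two cores in this assay, a number 32 percentage points higher (beyond the scatter) from compound 1 to compound 2 and a number 8 percentage points higher (within the scatter) from compound 3 to compound 4, 24 percentage points apart, beyond the scatter of two such steps. Read the other way, nitro in place of methoxy on the 4-bromobenzyl compounds gives a number 38 percentage points lower from compound 2 to compound 4 (beyond the scatter), and this drop does not match the one on the 3-bromobenzyl compounds: the same change on two cores in this assay, a number 14 percentage points lower (beyond the scatter) from compound 1 to compound 3 and a number 38 percentage points lower (beyond the scatter) from compound 2 to compound 4, 24 percentage points apart, beyond the scatter of two such steps. These two comparisons draw on the same four compounds and so form a single observation that the two changes do not add up in this series; they do not show why, nor how the change would behave on any other core.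

Going by these compounds, it remains open whether the benefit of 4-bromobenzyl is particular to methoxy or would also appear with an amine or a carboxylic acid on that aromatic carbon. Also open, on these data alone, is whether a longer chain in place of the benzyl carbon would keep the same dependence on the core.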